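Trifluoromethoxy for Fluoro: A Solubility Estimate

The compounds below may be only part of what the source reports. "The series", "measured", "known", "first", "only" and "open" are said of these compounds alone.

Measured so far:
compound 1, `Cc1cc(NC(=O)Nc2cc(F)ccc2F)c2ccccc2n1`: 500 nM
compound 2, `Cc1cc(NC(=O)Nc2ccccc2F)c2ccccc2n1`: 3800 nM
compound 3, `Cc1cc(NC(=O)Nc2ccc(Cl)cc2)c2ccccc2n1`: 1400 nM

In a physicochemical assay for solubility, at pH 7.4 (a lower number here means a less soluble compound, a higher number a more soluble compound), compound 2 gives the highest of the three numbers; compound 3 is nearest, and compound 1 is furthest. The unmeasured compound 4, `Cc1cc(NC(=O)Nc2ccccc2OC(F)(F)F)c2ccccc2n1`, differs from compound 2 in one place: trifluoromethoxy in place of fluoro on an aromatic carbon. The change sits on an aromatic carbon of a six-membered aromatic ring of carbon only, ortho to a large group.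

Among the compounds with values here, two measured steps bear on this. The step from compound 1 to compound 2, a 7.6-fold higher number from compound 1 to compound 2 (0.88 log units; beyond the scatter), shows that one fluorine fewer on that ring went with a clearly higher number in this assay. The step from compound 2 to compound 3, a 2.7-fold lower number from compound 2 to compound 3 (0.43 log units; beyond the scatter), shows that a different substituted phenyl went with a lower number. Compound 4 adds more heavy atoms than compound 2 carries at that position, so a modest drop beyond the scatter is expected, a 3.8-fold lower number from compound 2 to compound 4 (0.58 log units; beyond the scatter). Compound 4 is therefore estimated at 1000 nM, within a range from 300 nM to 3000 nM.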

Compound 4, solubility: 4600 nM
Estimate against measurement, compound 4: 4.6-fold (0.66 log units) below; the whole stated range lies below it.
By their numbers in this assay, from the lowest: compound 1; then compound 3; then compounds 2 and 4 (each within the scatter of the next).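

In this assay, trifluoromethoxy in place of fluoro on this aromatic carbon, ortho to a large group, gives a 1.2-fold higher number from compound 2 to compound 4 (0.08 log units; within the scatter) and so leaves the two compounds indistinguishable. Extra heavy atoms on this ring therefore do not always go with a lower number: a 7.6-fold higher number from compound 1 to compound 2 (0.88 log units; beyond the scatter) came with one fluorine fewer, yet compound 4 goes against that trend, carrying more heavy atoms than compound 2 while remaining within the scatter of it. No measurement shown here offers a reason for this result.

From the compounds shown here alone, it remains open whether methoxy, an amine or a carboxylic acid on this same carbon would also leave the number within the scatter of compound 2. Going by these compounds, it is equally open whether trifluoromethoxy would do so elsewhere on the ring.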